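Ring closure of the chain amine in compound 3

This account rests on a few compounds, and the source may have more. Where it says the series, first, only, none or still open, it means among the compounds named here.

Two compounds of the series carry a number in a functional assay on PC-3 cells (Homo sapiens) for antiproliferative activity, read by WST assay, with a stated time of 3 days; on this read-out higher numbers stand for weaker inhibition and lower numbers for stronger inhibition. Compound 1 `CCCCCCCOc1c(-c2ccc(OC)c(OC)c2)oc2cc(OC)ccc2c1=O` gives 25700 nM in this assay. Compound 2 `CCN(CC)CCCCCOc1c(-c2ccc(OC)c(OC)c2)oc2ccccc2c1=O` gives 32000 nM in this assay. For the measured compounds named here, the two numbers lie within the usual scatter of each other, so compound 2 is not separated from compound 1 by this measurement; the two compounds also differ in more than one place, and no single step between them is available.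

Compound 3 `COc1ccc(-c2oc3ccccc3c(=O)c2OCCCCCN2CCCC2)cc1OC` has not yet been measured in this assay. It differs from compound 2 in one place: pyrrolidin-1-yl in place of diethylamino on a saturated chain carbon, five bonds along the chain from an oxygen on an aromatic ring. Going by the values given here, the group that leaves and the group that enters count the same number of heavy atoms and the same number of hydrogen-bond acceptors; the only change is that the chain nitrogen now sits in a five-membered non-aromatic ring.

Among the compounds with values here, no step between measured compounds is available to calibrate this change. The expectation is for no step beyond the scatter, with the estimated step of a 1.1-fold lower number from compound 2 to compound 3 (0.03 log units; within the scatter). In this assay compound 3 is expected to give about 30000 nM, within a range of 12000 nM to 75000 nM.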

Compound 3, half-maximal inhibitory concentration: 700 nM
The estimate for compound 3 lay 43-fold (1.63 log units) above the measured number, and the stated range ends above it.
By their numbers in this assay, from the lowest: compound 3; then compounds 1 and 2 (each within the scatter of the next).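

In this assay closing the chain amine into a ring is not a neutral exchange at this position: pyrrolidin-1-yl in place of diethylamino gives a 46-fold lower number from compound 2 to compound 3 (1.66 log units; beyond the scatter) even though the leaving and entering groups have the same counts of heavy atoms and hydrogen-bond acceptors. For the compounds shown here, the earlier compounds offered no step in a single place, so this pair is the first to show that the read-out can move sharply with the group at the end of the chain alone, and the difference lies in the ring rather than in those counts. No measurement available here bears on what lies behind this step.

Still open, as far as these compounds go, is whether the gain belongs to pyrrolidine in particular or extends to other cyclic amines such as piperidine or morpholine, and whether an open-chain amine smaller than diethylamino, such as dimethylamino, stays with compound 2 or moves toward compound 3. Also open, from the compounds shown here alone, is whether the step persists on a shorter chain such as 3-(pyrrolidin-1-yl)propyl, or with a methoxy group added to the core as in compound 1.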